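The source may report more compounds than this note shows. Statements on the series, on what has been measured and on what is new or still open speak of the compounds shown alone.

Measured so far in a functional assay for agonist activity at Bile acid receptor (Homo sapiens), read by FRET; a lower number here means that less compound is needed, a higher number that more compound is needed for the effect:
compound 1 `CC(C)c1onc(-c2c(Cl)cccc2Cl)c1COc1ccc(-c2ccc3c(C(=O)O)nccc3c2)cc1` gives 380 nM
compound 2 `Cc1nc(C(=O)O)nc2ccc(-c3ccc(OCc4c(-c5c(Cl)cccc5Cl)noc4C(C)C)cc3)cc12` gives 140 nM
compound 3 `CCc1cc(C(=O)O)nc2ccc(-c3ccc(OCc4c(-c5c(Cl)cccc5Cl)noc4C(C)C)cc3)cc12` gives 75 nM

Compound 3 holds the lowest of the three numbers. Its gap to compound 2 lies within the scatter of this assay, so the two cannot be put in order. Its gap to compound 1 lies beyond the scatter, so compound 3 does need less compound than compound 1 for the same effect. Going by the values given here, no pair among the three differs in one place only, so no single structural step has yet been measured, and nothing is known about how a change at the position in question moves the number.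

Compound 4 `CCCOc1cc(C(=O)O)nc2ccc(-c3ccc(OCc4c(-c5c(Cl)cccc5Cl)noc4C(C)C)cc3)cc12` is the next compound. It differs from compound 3 in one place: propoxy in place of ethyl on an aromatic carbon. Both substituents are small and uncharged, and the only known variation at this position, across compounds 1 to 3, runs over different groups and different cores at once, so it does not isolate this exchange. A modest move in either direction, or none beyond the scatter, is expected.

The step from compound 3 to compound 4 is estimated at a 1.1-fold higher number from compound 3 to compound 4 (0.05 log units; within the scatter). Compound 4 is expected to give about 85 nM, with a likely range from 30 nM to 250 nM.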

Compound 4, half-maximal effective concentration: 59 nM
Beside the measured number, compound 4's estimate is 1.4-fold (0.16 log units) above it, and the stated range covers the measured number.
By their numbers in this assay, from the lowest: compounds 4, 3 and 2 (each within the scatter of the next, the first and the last beyond it); then compound 1.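

In this assay, going by these compounds alone, propoxy in place of ethyl on this aromatic carbon, opposite the ring nitrogen and meta to the carboxy group, gives a 1.3-fold lower number from compound 3 to compound 4 (0.10 log units; within the scatter), the first step that isolates a change in one place. The position therefore takes a group with more heavy atoms, including an oxygen attached directly to the aromatic carbon and counted as a hydrogen-bond acceptor, without a change beyond the scatter; compounds 1 to 3 could not show this, as no two of them differ in one place only. No measured evidence on the compounds bears on this result, so the step stands here as an observation without an explanation.

A single exchange cannot separate the contribution of the oxygen from that of the chain length, and a comparison of ethoxy, propyl or a longer alkoxy chain with compounds 3 and 4 would be needed to pull the two apart. Going by these compounds, it also remains open how far this tolerance extends to other kinds of group at the same carbon, such as an amine, an amide or a carboxylic acid.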